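Swapping a Piperidine Substituent on a Stilbene Amide

A few compounds are considered here, and "the series" means these few. Any claim that something is new, unique, unknown or untested is made for them only; others in the source may bear on it.

Compound 1 `COc1ccc(/C=C/c2cc(OC)cc(OC)c2/C=C/C(=O)N2CCCCC2C)cc1` gives 5770 nM in a functional assay on A549 cells (Homo sapiens) for inhibition, read by MTT assay, with a stated time of 48 h (on this read-out higher numbers stand for weaker inhibition and lower numbers for stronger inhibition), the second highest of the three numbers measured. Compound 2 `COc1ccc(/C=C/c2cc(OC)cc(OC)c2/C=C/C(=O)N2CCCCC2)cc1` gives 10600 nM, and compound 3 `COc1ccc(/C=C/c2cc(OC)cc(OC)c2/C=C/C(=O)NC(C)C)cc1` gives 2360 nM. Compound 4 `COc1ccc(/C=C/c2cc(OC)cc(OC)c2/C=C/C(=O)N2CCC(c3ccccc3)CC2)cc1` differs from compound 1 by 4-phenylpiperidin-1-yl in place of 2-methylpiperidin-1-yl on a carbonyl carbon. Three measured steps at the same carbonyl carbon bear on this: a 1.8-fold higher number from compound 1 to compound 2 (0.26 log units; within the scatter), a 2.4-fold lower number from compound 1 to compound 3 (0.39 log units; beyond the scatter) and a 4.5-fold lower number from compound 2 to compound 3 (0.65 log units; beyond the scatter). Only the move to the smaller isopropylamino group lowered the number beyond the scatter; replacing the ring methyl with hydrogen gave no clear change. Compound 4 instead carries the larger 4-phenylpiperidin-1-yl group, so for compound 4 a step of a 1.4-fold higher number from compound 1 to compound 4 (0.14 log units; within the scatter) is expected. The estimate for compound 4 is 8000 nM, within 3000 nM to 22000 nM.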

Compound 4, half-maximal inhibitory concentration: 6690 nM
Compound 4: the middle estimate sits 1.2-fold (0.08 log units) above what was measured; the range from low to high includes it.
By their numbers in this assay, from the lowest: compound 3; then compounds 1, 4 and 2 (each within the scatter of the next).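

In this assay, a larger group on the same carbonyl carbon brings no clear difference: 4-phenylpiperidin-1-yl in place of 2-methylpiperidin-1-yl gives a 1.2-fold higher number from compound 1 to compound 4 (0.06 log units; within the scatter), and phenyl in place of hydrogen on a saturated ring carbon gives a 1.6-fold lower number from compound 2 to compound 4 (0.20 log units; within the scatter). The added phenyl ring therefore does not set compound 4 apart from these two ring amides, whereas the isopropylamino compound stays separate, with a 2.8-fold higher number from compound 3 to compound 4 (0.45 log units; beyond the scatter). Nothing available explains these numbers. Still open, from the compounds shown here alone, is whether a morpholine ring or a longer chain in place of isopropylamino on a carbonyl carbon would give a number clearly different from that of compound 3.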